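A few compounds are considered here, and "the series" means these few. Any claim that something is new, unique, unknown or untested is made for them only; others in the source may bear on it.

Measured compounds:
- Compound 1 `Nc1nc(Cl)c2ncn(Cc3ccccc3CCl)c2n1`: in a functional assay on RXF 393 cells (Homo sapiens) for cytotoxicity, read by sulforhodamine B assay, with a stated time of 48 h (a lower number here means a stronger inhibitor of growth, a higher number a weaker inhibitor of growth), compound 1 gives "not determined" (no result reported)
- Compound 2 `ClCc1ccccc1Cn1cnc2c(Cl)nc(Cl)nc21`: 100 nM

For the measured compounds named here, compound 2 is thus the only compound with a number, and compound 1 gives nothing to compare it with. Compound 3 `ClCc1ccccc1Cn1cnc2c(Cl)ncnc21` is still to be tested. It differs from compound 2 in one place: hydrogen in place of chloro on an aromatic carbon. The chloromethyl group on the benzyl arm and the remaining chloro on the fused core stay where they are.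

Going by the values given here, since no measured pair shows what removing this chloro does, the expectation rests on compound 2 alone and on the small size of the change. The step from compound 2 to compound 3 is expected to be a 1.5-fold higher number from compound 2 to compound 3 (0.18 log units; within the scatter), small and most likely within the usual scatter, with at most a slight loss. Compound 3 is expected to give about 150 nM, in a range from 50 nM to 500 nM.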

Compound 3, concentration for 50% growth inhibition: 440 nM
For compound 3 the middle estimate is 2.9-fold (0.47 log units) below the measured one, within the range that was stated.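

In this assay, replacing the chloro between two ring nitrogen atoms with hydrogen gives a 4.4-fold higher number from compound 2 to compound 3 (0.64 log units; beyond the scatter) and so counts as a modest but real step. This shows that this carbon of the six-membered aromatic ring is not indifferent to what it carries, and that within this pair the chloro goes with the stronger growth inhibition. No measurement offered here explains the difference.

Compound 1, with an amino group at this carbon, gives "not determined" (no result reported) and so adds no number to the comparison. As far as these compounds go, how a methoxy group or a bromo at the same carbon would compare with chloro and hydrogen stays open, as does the contribution of the remaining chloro and of the chloromethyl group on the benzyl arm.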